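The source may report more compounds than this note shows. Statements on the series, on what has been measured and on what is new or still open speak of the compounds shown alone.

Of the compounds shown here, three built on one shared core have been tested in an ADME assay on Vero cells (Chlorocebus sabaeus) for cytotoxicity, read by MTT assay; on this read-out higher numbers stand for lower toxicity in this test and lower numbers for higher toxicity in this test. Compound 1 `Cn1nc(C(F)(F)F)cc1C(=O)Nc1ccc(S(=O)(=O)N2CCCCCCC2)cc1` gives 16000 nM in this assay, the second highest of the three numbers. Compound 2 `Cn1nc(C(F)(F)F)cc1C(=O)Nc1ccc(S(=O)(=O)n2ccc3ccccc32)cc1` gives 13000 nM, and the step of a 1.2-fold lower number from compound 1 to compound 2 (0.09 log units; within the scatter) stays within the scatter. Compound 3 `Cn1nc(C(F)(F)F)cc1C(=O)Nc1ccc(S(=O)(=O)N2CCNCC2)cc1` gives 126000 nM, the highest number of the three, reached through a 7.9-fold higher number from compound 1 to compound 3 (0.90 log units; beyond the scatter) and through a 9.7-fold higher number from compound 2 to compound 3 (0.99 log units; beyond the scatter).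

Compound 4 `Cn1nc(C(F)(F)F)cc1C(=O)Nc1ccc(S(=O)(=O)N2CCC(O)CC2)cc1` has not yet been measured. It differs from compound 1 at one place: a group of 7 heavy atoms (5 carbon, 1 nitrogen, 1 oxygen; one six-membered non-aromatic ring with 1 hetero atom) in place of a group of 8 heavy atoms (7 carbon, 1 nitrogen; one eight-membered non-aromatic ring with 1 hetero atom), on a sulfonyl sulfur. The ring that enters is a six-membered non-aromatic ring, as in compound 3, and it brings one hydrogen-bond donor and one hydrogen-bond acceptor, whereas the eight-membered ring that leaves brings none. The two steps that bear on this change are a 7.9-fold higher number from compound 1 to compound 3 (0.90 log units; beyond the scatter) and a 9.7-fold higher number from compound 2 to compound 3 (0.99 log units; beyond the scatter), both modest and beyond the scatter, and both move towards a higher number when a six-membered non-aromatic ring replaces a larger group on the sulfonyl sulfur. The step of a 1.2-fold lower number from compound 1 to compound 2 (0.09 log units; within the scatter) shows that exchanging one ring group for another need not move the number at all. For compound 4 a rise beyond the scatter is expected, with a 3.1-fold higher number from compound 1 to compound 4 (0.49 log units; beyond the scatter). The estimate for compound 4 is 50000 nM, between 20000 nM and 130000 nM.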

Compound 4, half-maximal cytotoxic concentration: 274000 nM
Compound 4: middle estimate off by 5.5-fold (0.74 log units), on the low side; the measured number lies above the stated range.
By their numbers in this assay, from the lowest: compounds 2 and 1 (each within the scatter of the next); then compound 3; then compound 4.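

In this assay, 4-hydroxypiperidin-1-yl on the sulfonyl sulfur gives the largest rises seen so far at this position, both large (a 17-fold higher number from compound 1 to compound 4 (1.23 log units; beyond the scatter)) and (a 21-fold higher number from compound 2 to compound 4 (1.32 log units; beyond the scatter)), so compound 4 now has the highest number of the four and the lowest toxicity in this test. Within the data shown here, the change also separates two six-membered non-aromatic rings, a difference the earlier compounds could not show: 4-hydroxypiperidin-1-yl in place of piperazin-1-yl gives a modest step beyond the scatter (a 2.2-fold higher number from compound 3 to compound 4 (0.34 log units; beyond the scatter)), so piperazin-1-yl is not the only six-membered ring here that lifts the number well above compound 1 and compound 2. No measurement shown accounts for these rises.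

As far as these compounds go, the step from the eight-membered ring to 4-hydroxypiperidin-1-yl changes the ring and adds the hydroxyl at once, so the share of each remains unknown. Plain piperidin-1-yl, with no hydroxyl, would separate the two, and morpholin-4-yl or 4-aminopiperidin-1-yl would show whether other six-membered rings on the sulfonyl sulfur give similar numbers.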